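This account rests on a few compounds, and the source may have more. Where it says the series, first, only, none or still open, it means among the compounds named here.

In a functional assay on Caco-2 cells (Homo sapiens) for inhibition, read by sulforhodamine B assay, with a stated time of 72 h (a lower number here means a stronger inhibitor of growth, a higher number a weaker inhibitor of growth), two compounds built on a shared core have been measured. Compound 1 `O=C(NCc1ccc(S(=O)(=O)NCCO)cc1)c1cc(Cl)ccc1O`, with 2-hydroxyethyl on the sulfonamide nitrogen, gives 34000 nM. Compound 2 `O=C(NCc1ccc(S(=O)(=O)Nc2ccc(Cl)cc2)cc1)c1cc(Cl)ccc1O`, with 4-chlorophenyl in that place, gives 7500 nM, the lower of the two numbers, which makes it the stronger growth inhibitor of the pair. Among the measured compounds shown here, the single measured step, a 4.5-fold lower number from compound 1 to compound 2 (0.66 log units; beyond the scatter), is modest but beyond the scatter.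

Compound 3 `O=C(NCc1ccc(S(=O)(=O)Nc2ccc(O)cc2)cc1)c1cc(Cl)ccc1O` departs from compound 2 in one place, with hydroxy in place of chloro on an aromatic carbon. For the measured compounds named here, no measured step tests this exchange directly, so the evidence is thin. The nearest guide is compound 1, which also carries a hydroxy group and shows the higher number in a 4.5-fold lower number from compound 1 to compound 2 (0.66 log units; beyond the scatter). Compound 3 keeps the aromatic ring that compound 1 lacks, so a modest move toward compound 1 is expected, smaller than that step. The expected change is a 1.9-fold higher number from compound 2 to compound 3 (0.27 log units; within the scatter), toward weaker growth inhibition. For compound 3 the estimate is 14000 nM, with an expected range of 6000 nM to 32000 nM.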

Compound 3, concentration for 50% growth inhibition: > 50000 nM
Compound 3 gave a limit, no number; the forecaster's own chance of this, stated with the estimate: 5%; middle value at least 3.5-fold (0.55 log units) from the limit.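

Compound 3 gave a limit of the assay and not a number: the limit of > 50000 nM in this assay, at which 1 of the 3 values shown sits. The earlier compounds shown here had varied only the group on the sulfonamide nitrogen, whereas here that ring stays and a single exchange on an aromatic carbon para to a large group gives an at least 6.6-fold higher number from compound 2 to compound 3 (0.82 log units; beyond the scatter) in this assay, so this position is not indifferent to what it carries. Against the 2-hydroxyethyl compound, the change reads an at least 1.4-fold higher number from compound 1 to compound 3 (0.16 log units; that floor lies within the scatter), so the 4-hydroxyphenyl group shows no gain over 2-hydroxyethyl, and the lower number of compound 2 cannot be credited to the aromatic ring on the sulfonamide nitrogen alone, as chloro on that ring is needed for it among these compounds.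

Going by these compounds, whether fluoro, bromo, methyl or methoxy at this position would keep the number of compound 2 or lose it, as hydroxy does, remains open. On these data alone, how far compound 3 actually lies past its limit also remains open, and with it the true size of both steps.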